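Removing the Pyrrolidinylmethyl Arm from Compound 2

The source may hold more compounds than are shown below. What is called first, only, known or untested is meant among the compounds shown, and "the series" means these compounds.

Three compounds share a core built around a carbonyl linking two aromatic rings, and all were measured in a functional assay on THP-1 cells (Homo sapiens) for inhibition, read by ELISA, with stated times of 30 min and 24 h, tested at 10 uM; a lower number here means a weaker effect, a higher number a stronger effect of the compound at the concentration tested. Compound 1 `COc1cc(O)c(C(=O)c2ccccc2Br)c(OC)c1` gives 72%. Compound 2 `COc1cc(OC)c(C(=O)c2ccccc2F)c(O)c1CN1CCCC1` gives 87%. Compound 3 `COc1cc(OC)c(C(=O)c2ccccc2Br)c(O)c1CN1CCCC1` gives 100%. On these numbers compound 2 stands second of three: compound 3 lies a number 13 percentage points higher from compound 2 to compound 3 (beyond the scatter), and compound 1 sits lower than compound 2 by a gap beyond the scatter.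

Compound 4 `COc1cc(O)c(C(=O)c2ccccc2F)c(OC)c1` has not yet been measured. Its difference from compound 2 is hydrogen in place of (pyrrolidin-1-yl)methyl on an aromatic carbon.

The step that bears most directly on this change runs the other way: a number 28 percentage points higher from compound 1 to compound 3 (beyond the scatter), where the (pyrrolidin-1-yl)methyl group is added rather than removed, though on a bromo-bearing partner. The step of a number 13 percentage points higher from compound 2 to compound 3 (beyond the scatter) concerns the halogen only and is kept fixed here. Reversing the pyrrolidinylmethyl addition is therefore expected to cost activity in this assay by a similar modest amount, so the expected step is a number 28 percentage points lower from compound 2 to compound 4 (beyond the scatter). Compound 4 is thus estimated at 59%, within a range from 42% to 76%.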

Compound 4, a percentage reported as activity, at one concentration (the size of the read-out at that concentration, not a potency): 71%
For compound 4 the middle estimate is 12 percentage points below the measured one; the measured number falls inside the stated range.
By their numbers in this assay, from the lowest: compounds 4 and 1 (each within the scatter of the next); then compound 2; then compound 3.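

In this assay, the loss on removing the (pyrrolidin-1-yl)methyl group is now measured directly on the fluoro-bearing partner, and the step is a number 16 percentage points lower from compound 2 to compound 4 (beyond the scatter). Within the data shown here, until now, the only measured step for this change was on the bromo-bearing partner, so this result shows that the group is linked to a higher number with either halogen, and the two step sizes agree: the same change on two cores in this assay, a number 28 percentage points higher (beyond the scatter) from compound 1 to compound 3 and a number 16 percentage points higher (beyond the scatter) from compound 4 to compound 2, 12 percentage points apart, within the scatter of two such steps. With the group gone, fluoro in place of bromo gives a number 1 percentage points lower from compound 1 to compound 4 (within the scatter), but this step cannot be said to differ from the halogen step with the group present: the same change on two cores in this assay, a number 13 percentage points higher (beyond the scatter) from compound 2 to compound 3 and a number 1 percentage points higher (within the scatter) from compound 4 to compound 1, 12 percentage points apart, within the scatter of two such steps.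

The compounds shown leave open whether the higher number needs the five-membered ring, the nitrogen or simply a carbon substituent on this aromatic carbon, a question that a piperidin-1-ylmethyl group, a dimethylaminomethyl group and a plain methyl group could help to separate. All of these numbers also come from a single concentration, so they show only a stronger or weaker effect at that concentration.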